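Swapping a Pyridyl for an Acetyl on a Porcupine Inhibitor

The compounds below may be only part of what the source reports. "The series", "measured", "known", "first", "only" and "open" are said of these compounds alone.

Compound 2 `O=C(CSc1nc2c(c(=O)n1-c1ccccc1)SCC2)Nc1ccc(-c2ccncc2)cc1` gives 3 nM in an assay on L cells for inhibition of Protein-serine O-palmitoleoyltransferase porcupine (Mus musculus), read by reporter gene assay, with a stated time of 24 h (on this read-out higher numbers stand for an effect only at larger amounts of compound and lower numbers for an effect already at smaller amounts), the lowest of the two numbers shown, while compound 1 `O=C(CSc1nc2c(c(=O)n1-c1ccccc1)SCC2)Nc1nc2ccc(Cl)cc2s1` gives 40 nM, a larger number that lies beyond the usual scatter. Compound 3 `CC(=O)c1ccc(NC(=O)CSc2nc3c(c(=O)n2-c2ccccc2)SCC3)cc1` differs from compound 2 in a single place: acetyl in place of pyridin-4-yl on an aromatic carbon. Going by the values given here, no measured pair shows what this exchange does, so its effect must be guessed. A moderate loss is expected, with the effect appearing only at larger amounts of compound. The step expected is a 10-fold higher number from compound 2 to compound 3 (1.00 log units; beyond the scatter). Compound 3 is estimated at 30 nM, between 8 nM and 150 nM.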

Compound 3, half-maximal effective concentration: > 1000 nM
Compound 3: only a limit was reported; the forecaster's own chance of this, stated with the estimate: 5%; middle value at least 33-fold (1.52 log units) from the limit.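

Acetyl in place of pyridin-4-yl, with the hydrogen-bond acceptor count unchanged, gives an at least 330-fold higher number from compound 2 to compound 3 (2.52 log units; beyond the scatter) in this assay, so that count alone does not decide activity at this position. 4-Acetylphenyl in place of 6-chloro-1,3-benzothiazol-2-yl on an amide-type nitrogen gives an at least 25-fold higher number from compound 1 to compound 3 (1.39 log units; beyond the scatter). Both steps rest on a limit for compound 3, not a number: the limit of > 1000 nM in this assay, at which 1 of the 3 values shown sits.

The compounds shown leave open whether the ring or its nitrogen matters more, a question that a phenyl or pyridin-3-yl group at this place could answer.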